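A few compounds are considered here, and "the series" means these few. Any claim that something is new, unique, unknown or untested is made for them only; others in the source may bear on it.

Measured in a functional assay on PC-3M cells (Homo sapiens) for antiproliferative activity, read by microscopy, with a stated time of 24 h; a lower number here means a stronger inhibitor, a higher number a weaker inhibitor:
- compound 1 `O[C@H]1CC[C@H](Nc2ncnc3c2c(-c2ccccc2)c(-c2ccccc2)n3Cc2ccccc2)CC1`: > 20000 nM
- compound 2 `COc1ccc(-c2c(-c3ccc(OC)cc3)n(Cc3ccccc3)c3ncn(CCCO)c(=N)c23)cc1`: > 20000 nM

Both values are limits of the assay, not numbers. Compound 2 stands at the limit of > 20000 nM in this assay, at which 2 of the 2 values shown sit.

The next compound, compound 3 `COc1ccc(-c2c(-c3ccc(OC)cc3)n(Cc3ccccc3)c3ncn([C@H]4CC[C@H](OC)CC4)c(=N)c23)cc1`, has not yet been measured. It carries 4-methoxycyclohexyl in place of 3-hydroxypropyl on an aromatic nitrogen. Among the compounds with values here, no measured step gauges this change, so no shift beyond the scatter is expected in this assay, and the expected step is a number no higher from compound 2 to compound 3 (the limit leaves the size open). For compound 3 the estimated value is 20000 nM, with an expected range from 6000 nM to 40000 nM.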

Compound 3, half-maximal inhibitory concentration: > 20000 nM
Compound 3: only a limit was reported (the forecaster's own chance of this, stated with the estimate: 60%); the middle value sits exactly at the limit.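

Compound 2 and compound 3 both give only a limit, so no step can be read between them: the limit of > 20000 nM in this assay, at which 3 of the 3 values shown sit.

The compounds shown leave open how 4-methoxycyclohexyl compares with 3-hydroxypropyl in this assay, since none gives a measured number.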